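The source may hold more compounds than are shown below. What is called first, only, known or untested is meant among the compounds shown, and "the series" means these compounds.

Going by the values given here, compound 3 `COc1cc2c(Nc3nc4ccc(C(=O)Nc5c(C)cccc5C)cc4s3)ncnc2cc1OCCCN1CCCC1` gives 15700 nM in a functional assay on K562 cells (Homo sapiens) for cytotoxicity, read by WST assay, with a stated time of 72 h (a lower number here means a stronger inhibitor, a higher number a weaker inhibitor), the highest of the three numbers so far. Compound 1 `COc1cc2c(Nc3nc4ccc(C(=O)Nc5c(C)cccc5Cl)cc4s3)ncnc2cc1OCCCN1CCC(C)CC1` gives 8300 nM in this assay, within the scatter of compound 3, while compound 2 `COc1cc2c(Nc3nc4ccc(C(=O)Nc5c(C)cc(C)cc5C)cc4s3)ncnc2cc1OCCCN1CCCC1` gives 4300 nM in this assay; the step of a 3.7-fold higher number from compound 2 to compound 3 (0.56 log units; beyond the scatter) is the only one beyond the scatter.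

Compound 4 `COc1cc2c(Nc3nc4ccc(C(=O)Nc5c(C)cccc5Cl)cc4s3)ncnc2cc1OCCCN1CCCC1` differs from compound 3 by chloro in place of methyl on an aromatic carbon. Among the compounds with values here, no measured step covers this exchange; the closest comparison is compound 1, which carries the same chloro-bearing amide and sits within the scatter of compound 3. The expected step of a 1.7-fold lower number from compound 3 to compound 4 (0.24 log units; within the scatter) is therefore small, with the number perhaps a little lower. Compound 4 is expected to give about 9000 nM in this assay, in the range 3500 nM to 23000 nM.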

Compound 4, half-maximal inhibitory concentration: 13300 nM
Compound 4: middle estimate off by 1.5-fold (0.17 log units), on the low side; measured number inside the range.
By their numbers in this assay, from the lowest: compounds 2, 1, 4 and 3 (each within the scatter of the next, the first and the last beyond it).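

In this assay, chloro in place of methyl on this aromatic carbon, ortho to a large group, leaves the number within the scatter, with a 1.2-fold lower number from compound 3 to compound 4 (0.07 log units; within the scatter). Only the 2,4,6-trimethylphenyl amide stands apart so far, with a 3.1-fold higher number from compound 2 to compound 4 (0.49 log units; beyond the scatter) beside a 3.7-fold higher number from compound 2 to compound 3 (0.56 log units; beyond the scatter). Pyrrolidin-1-yl in place of 4-methylpiperidin-1-yl on the saturated chain carbon also stays within the scatter, with a 1.6-fold higher number from compound 1 to compound 4 (0.20 log units; within the scatter).

Nothing available explains these numbers. Open, on these data alone, is whether a methoxy or a fluoro on this aromatic carbon, or a morpholine at the chain end, would shift the number beyond the scatter.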